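Chalcone amine chain variations against amine oxidase A

The source may hold more compounds than are shown below. What is called first, only, known or untested is meant among the compounds shown, and "the series" means these compounds.

Measured so far:
Compound 1 `CCN(CC)CCCOc1ccc(C(=O)/C=C/c2ccc(N(C)C)cc2)c(O)c1`: 47100 nM
Compound 2 `CCN(CCCOc1ccc(C(=O)/C=C/c2ccc(N(C)C)cc2)c(O)c1)Cc1ccccc1OC`: 26300 nM

In an assay on isolated protein for inhibition of Amine oxidase [flavin-containing] A (Homo sapiens) (on this read-out lower numbers stand for stronger inhibition and higher numbers for weaker inhibition), compound 2 gives 26300 nM, and compound 1 gives 47100 nM; the two lie within the scatter of each other. Compound 3 `CCN(CCCCOc1ccc(C(=O)/C=C/c2ccc(N(C)C)cc2)c(O)c1)Cc1ccccc1` differs from compound 2 by (benzyl(ethyl)amino)methyl in place of ethyl(2-methoxybenzyl)amino on a saturated chain carbon, three bonds along the chain from an oxygen on an aromatic ring. Within the data shown here, the one measured step that touches this part of the molecule, a 1.8-fold lower number from compound 1 to compound 2 (0.25 log units; within the scatter), stayed within the scatter, so no shift beyond the scatter is expected in this assay either. Compound 3 is therefore estimated at 30000 nM, between 12000 nM and 80000 nM, which is expected to mean a 1.1-fold higher number from compound 2 to compound 3 (0.06 log units; within the scatter).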

Compound 3, half-maximal inhibitory concentration: 77300 nM
For compound 3 the middle estimate is 2.6-fold (0.41 log units) below the measured one; measured number inside the range.
By their numbers in this assay, from the lowest: compounds 2, 1 and 3 (each within the scatter of the next, the first and the last beyond it).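

In this assay, this position gives its first step beyond the scatter, a 2.9-fold higher number from compound 2 to compound 3 (0.47 log units; beyond the scatter), with (benzyl(ethyl)amino)methyl in place of ethyl(2-methoxybenzyl)amino. The same entering group in place of diethylamino stays within the scatter, a 1.6-fold higher number from compound 1 to compound 3 (0.22 log units; within the scatter), so the size of the change depends on which amino group it replaces. Nothing measured here explains this difference. The compounds shown leave open how a ring amine such as piperidine or morpholine at this position would read in this assay, and whether a 2-methoxybenzyl group on the amine of compound 3 would shift its number.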